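The source may hold more compounds than are shown below. What is called first, only, known or untested is meant among the compounds shown, and "the series" means these compounds.

Working notes on the series. Two compounds carry a measurement so far. Compound 1 `CCc1ccc(NC(=O)N[C@@H](C)c2ccccc2)cc1` gives in an ADME assay on the whole organism with Oryza sativa as the target, tested at 1 uM (on this read-out lower numbers stand for a stronger effect and higher numbers for a weaker effect at the one concentration tested), a value of 95%. Compound 2 `CCCCCCc1ccc(NC(=O)N[C@@H](C)c2ccccc2)cc1` gives in this assay a value of 100%. For the measured compounds named here, the one step between them, a number 5 percentage points higher from compound 1 to compound 2 (within the scatter), lies within the scatter, so the two numbers are to be read as the same; compound 2 holds the numerically larger of the two, its nearest neighbour being compound 1.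

Compound 3 `CCOC(=O)c1ccc(NC(=O)N[C@@H](C)c2ccccc2)cc1` has not yet been measured in this assay. It differs from compound 2 in one place: ethoxycarbonyl in place of hexyl on an aromatic carbon. Going by the values given here, the only measured step, a number 5 percentage points higher from compound 1 to compound 2 (within the scatter), concerns a chain grown on a saturated carbon two bonds from the ring, not a group on the aromatic carbon itself, and it was within the scatter. Among the compounds with values here, no measured step therefore speaks directly to an ethoxycarbonyl entering for hexyl. What remains is that compound 2 sits at 100%, near the upper end of the read-out, so downward room exists while upward room is small. For compound 3 the estimate is 88%, with a range from 65% to 100%. The step this estimate implies, a number 12 percentage points lower from compound 2 to compound 3 (beyond the scatter), is an expectation only.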

Compound 3, a percentage reported as activity, at one concentration (the size of the read-out at that concentration, not a potency): 97%
For compound 3 the middle estimate is 9 percentage points below the measured one; the range from low to high includes it.
By their numbers in this assay, from the lowest: compounds 1, 3 and 2 (each within the scatter of the next).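

In this assay ethoxycarbonyl in place of hexyl on the aromatic carbon gives a number 3 percentage points lower from compound 2 to compound 3 (within the scatter) and ethoxycarbonyl in place of ethyl on the same carbon gives a number 2 percentage points higher from compound 1 to compound 3 (within the scatter) so neither exchange separates the compounds. These steps are the first in the series made at the aromatic carbon itself, and they show that a group holding oxygen, a double bond outside aromatic rings and hydrogen-bond acceptors reads the same here as the carbon-only hexyl and ethyl chains; across compound 1, compound 2 and compound 3 the three numbers stand within the scatter of one another, and none of these compounds goes against that reading. No supporting measurement bears on this result, so it stands as a reading of the numbers alone.

What the compounds shown leave open is whether any group on this aromatic carbon, para to a large group, can move the read-out beyond the scatter at all. An amine or a carboxylic acid there would test this, since neither a free nitrogen nor an acid stands among the three groups shown.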